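Tellurium for Selenium on a Shared Core

This account rests on a few compounds, and the source may have more. Where it says the series, first, only, none or still open, it means among the compounds named here.

Going by the values given here, compound 3 `COc1ccc(N(CC(=O)NCCC[Se]c2ccccc2)C(=O)CCSC2=C(C)C(=O)c3ccccc3C2=O)cc1` sits, in a functional assay on A-431 cells (Homo sapiens) for cytotoxicity, read by MTT assay, with a stated time of 24 h (a higher number here means a weaker inhibitor, a lower number a stronger inhibitor), at 17000 nM, level with compound 1 `COc1ccc(N(CC(=O)NCCCSc2ccccc2)C(=O)CCSC2=C(C)C(=O)c3ccccc3C2=O)cc1` at 17000 nM, the two together the highest of the three numbers known; compound 2 `O=C(COC(=O)/C=C/c1ccccc1)NCCC[Te]c1ccccc1` gives 6000 nM, a clearly lower number. Compound 4 `COc1ccc(N(CC(=O)NCCC[Te]c2ccccc2)C(=O)CCSC2=C(C)C(=O)c3ccccc3C2=O)cc1` differs from compound 3 by a group of 7 heavy atoms (6 carbon, 1 tellurium; one six-membered aromatic ring of carbon only) in place of a group of 7 heavy atoms (6 carbon, 1 selenium; one six-membered aromatic ring of carbon only), on a saturated chain carbon, three bonds along the chain from an amide-type nitrogen. Among the compounds with values here, the one measured step that bears on this, no change at the digits printed from compound 1 to compound 3 (within the scatter), exchanged sulfur for selenium at the same place without moving the number. Within the data shown here, compound 2 carries tellurium but on a different core, so its value shows only that a tellurium compound can reach a lower number. Compound 4 is therefore expected to move little, the step of a 1.4-fold lower number from compound 3 to compound 4 (0.15 log units; within the scatter) being at most a modest gain. The estimate for compound 4 is 12000 nM, between 4000 nM and 30000 nM.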

Compound 4, half-maximal inhibitory concentration: 1000 nM
Compound 4: the middle estimate sits 12-fold (1.08 log units) above what was measured; the whole stated range lies above it.
By their numbers in this assay, from the lowest: compound 4; then compound 2; then compounds 1 and 3 (each within the scatter of the next).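

At this place, the saturated chain carbon three bonds along from the amide-type nitrogen, the identity of the heavy atom can matter a great deal: in this assay, tellurium in place of selenium gives a 17-fold lower number from compound 3 to compound 4 (1.23 log units; beyond the scatter), and tellurium in place of sulfur gives a 17-fold lower number from compound 1 to compound 4 (1.23 log units; beyond the scatter). The earlier sulfur-to-selenium step, no change at the digits printed from compound 1 to compound 3 (within the scatter), had hidden this, so on the shared core the number does not shift evenly across the three elements. Nothing measured here explains the drop.

As far as these compounds go, it remains open whether the tellurium effect survives a longer chain between the amide-type nitrogen and tellurium, or a methyl group on tellurium in place of the aromatic ring.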